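A Chlorine Swap on the Benzyl Arm of Compound 1

This account rests on a few compounds, and the source may have more. Where it says the series, first, only, none or still open, it means among the compounds named here.

Compound 1, `COC(=O)[C@H](CCSC)NC(=O)c1ccc(NCc2cncn2Cc2ccccc2C)cc1-c1ccccc1`, has been tested in a functional assay on NIH3T3 cells (Mus musculus); a higher number here means that more compound is needed for the effect, a lower number that less compound is needed. In this assay compound 1 reaches only a limit of the assay, > 10 uM. Compound 2, `CSCC[C@H](NC(=O)c1ccc(NCc2cncn2Cc2ccccc2C)cc1-c1ccccc1)C(=O)O`, differs from compound 1 in a single place. In this assay compound 2 likewise reaches only a limit, > 10 uM. The step that the two limits leave unreadable from compound 1 to compound 2 cannot be read in size or direction because of the limit of > 10 uM in this assay, at which 2 of the 2 values shown sit. Compound 3, `COC(=O)[C@H](CCSC)NC(=O)c1ccc(NCc2cncn2Cc2cccc(Cl)c2)cc1-c1ccccc1`, has not yet been measured; it carries 3-chlorophenyl in place of 2-methylphenyl on a saturated chain carbon bound to an aromatic nitrogen. Within the data shown here, no measured step touches this part of the shared core, so the only guide is that both known values sit at the limit, and nothing points to a rise or a fall beyond the scatter. The estimated step is a step that the limit leaves unreadable from compound 1 to compound 3. Compound 3 is expected to give 15 uM in this assay, somewhere between 5 uM and 50 uM, most likely again reported only as a limit.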

Compound 3, concentration for half-maximal effect: > 10 uM
Compound 3: only a limit was reported (the forecaster's own chance of this, stated with the estimate: 75%); the middle value does not contradict the limit.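

Compound 1, compound 2 and compound 3 all sit at a limit in this assay, so no step between them can be read: the limit of > 10 uM in this assay, at which 3 of the 3 values shown sit.

The compounds shown leave open what concentration each one actually needs, and so whether 3-chlorophenyl in place of 2-methylphenyl changes anything.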